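Replacing 3-hydroxyphenyl with 2,3-dichlorophenyl

A few compounds are considered here, and "the series" means these few. Any claim that something is new, unique, unknown or untested is made for them only; others in the source may bear on it.

Among the compounds with values here, in a functional assay on A549 cells (Homo sapiens) for cytotoxicity, read by MTT assay, with a stated time of 72 h (on this read-out lower numbers stand for stronger inhibition and higher numbers for weaker inhibition), compound 3 (`COc1ccc(/C=C2\CCC/C(=C\c3cccc(O)c3)C2=O)cc1OC`) gives 4300 nM, the only true number so far. Compound 1 (`COc1ccc(/C=C2\CCC/C(=C\c3ccccc3Br)C2=O)cc1OC`) gives > 20000 nM, which is a limit. Compound 2 (`COc1ccc(/C=C2\CCC/C(=C\c3ccc(OC)c(OC)c3)C2=O)cc1`) gives > 20000 nM, also a limit. The data are therefore dominated by the limit of > 20000 nM in this assay, at which 2 of the 3 values shown sit, and the comparison between the two limited compounds yields only a step that the two limits leave unreadable from compound 1 to compound 2.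

Compound 4 (`COc1ccc(/C=C2\CCC/C(=C\c3cccc(Cl)c3Cl)C2=O)cc1OC`) differs from compound 3 in one group: 2,3-dichlorophenyl in place of 3-hydroxyphenyl on a double-bonded chain carbon bound to a double-bonded ring carbon.

Within the data shown here, two measured steps bear on this change: an at least 4.6-fold lower number from compound 1 to compound 3 (0.66 log units; beyond the scatter) and an at least 4.6-fold lower number from compound 2 to compound 3 (0.66 log units; beyond the scatter). Both lie beyond the scatter, but each is open-ended, so neither fixes the true gap. Among the measured compounds shown here, the closer precedent is the first, since the 2-bromophenyl group of compound 1, like the 2,3-dichlorophenyl group, carries halogen and no hydroxy group. Removing the 3-hydroxyphenyl group is thus expected to move the number upward, towards the limit, by a modest step or more.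

The expected change in this assay is a 3.7-fold higher number from compound 3 to compound 4 (0.57 log units; beyond the scatter). For compound 4 the estimated value is 16000 nM. The expected range for compound 4 runs from 5000 nM to 45000 nM.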

Compound 4, half-maximal inhibitory concentration: > 20000 nM
Compound 4: only a limit was reported (the forecaster's own chance of this, stated with the estimate: 55%); middle value at least 1.2-fold (0.09 log units) from the limit.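

At this place, on a double-bonded chain carbon bound to a double-bonded ring carbon, 2,3-dichlorophenyl in place of 3-hydroxyphenyl gives in this assay an at least 4.6-fold higher number from compound 3 to compound 4 (0.66 log units; beyond the scatter), a step beyond the scatter but open-ended. With 2,3-dichlorophenyl, a second halogen-bearing group joins 2-bromophenyl without a readable number, so among the compounds shown, 3-hydroxyphenyl alone gives a true value, while compound 1, compound 2 and compound 4 carry only a limit. The steps among these three compounds cannot be read, and the series now gathers at one ceiling: the limit of > 20000 nM in this assay, at which 3 of the 4 values shown sit.

Where the true values of compound 1, compound 2 and compound 4 lie, and any order among them, stays open. Also open, as far as these compounds go, is whether the readable number of compound 3 is tied to the hydroxy group itself, which a 3-methoxyphenyl or 3-aminophenyl group in the same place would begin to test.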